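A few compounds are considered here, and "the series" means these few. Any claim that something is new, unique, unknown or untested is made for them only; others in the source may bear on it.

Measured so far in a functional assay on PC-3 cells (Homo sapiens) for antiproliferative activity, read by MTT assay, with a stated time of 48 h; a lower number here means a stronger inhibitor, a higher number a weaker inhibitor:

compound 1, `NS(=O)(=O)c1ccc(Nc2ncc(F)c(Nc3nc4ccccc4s3)n2)cc1`: > 50000 nM, a limit of the assay, not a number
compound 2, `NS(=O)(=O)c1ccc(Nc2ncc(F)c(Nc3nc4ccc(Cl)cc4s3)n2)cc1`: 1430 nM
compound 3, `Cc1cnc(Nc2ccc(S(N)(=O)=O)cc2)nc1Nc1nc2ccccc2s1`: > 50000 nM, again a limit of the assay, not a number

Compound 1 and compound 2 differ in one place: chloro in place of hydrogen on an aromatic carbon. This change gives an at least 34-fold lower number from compound 1 to compound 2 (1.54 log units; beyond the scatter). The core of compound 3 differs from the core of compound 1 by methyl in place of fluoro on an aromatic carbon. The step that the two limits leave unreadable from compound 1 to compound 3 stays unreadable because the limit of > 50000 nM in this assay, at which 2 of the 3 values shown sit, sets both of its values.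

Compound 4, `Cc1cnc(Nc2ccc(S(N)(=O)=O)cc2)nc1Nc1nc2ccc(Cl)cc2s1`, is not yet measured in this assay. It stands to compound 3 as compound 2 stands to compound 1: chloro in place of hydrogen on an aromatic carbon, the same change at the same place. For compound 4 the expected step is an at least 8.3-fold lower number from compound 3 to compound 4 (0.92 log units; beyond the scatter), resting on the measured step of an at least 34-fold lower number from compound 1 to compound 2 (1.54 log units; beyond the scatter). The value of compound 3 is a limit, and the starting point of the expected step is not a fixed number, so the range is kept wide. For compound 4 the estimate in this assay is 6000 nM, with a likely range from 1200 nM to 50000 nM.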

Compound 4, half-maximal inhibitory concentration: 5400 nM
The estimate for compound 4 lay 1.1-fold (0.05 log units) above the measured number; the range from low to high includes it.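

In this assay, chloro in place of hydrogen on an aromatic carbon carries over to a second core and gives an at least 9.2-fold lower number from compound 3 to compound 4 (0.96 log units; beyond the scatter). This shows the same direction on both cores, but it does not show that the change has the same size on each: the same change on two cores in this assay, an at least 34-fold lower number (1.54 log units; beyond the scatter) from compound 1 to compound 2 and an at least 9.2-fold lower number (0.96 log units; beyond the scatter) from compound 3 to compound 4; the limit leaves it open whether they differ With chloro present on both cores, methyl in place of fluoro gives a 3.8-fold higher number from compound 2 to compound 4 (0.58 log units; beyond the scatter), whereas the corresponding step without chloro cannot be read: the limit of > 50000 nM in this assay, at which 2 of the 4 values shown sit.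

On these data alone, whether the lower number is particular to chloro remains open, as a bromo, methoxy or trifluoromethyl group at the same place would be needed to test this on both cores. Also open, as far as these compounds go, is how the series responds to an amine, a carboxylic acid or a longer chain in place of the fluoro or methyl group.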